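The source may report more compounds than this note shows. Statements on the series, on what has been measured and on what is new or still open speak of the compounds shown alone.

For the measured compounds named here, in a functional assay on HCT-116 cells (Homo sapiens), read by MTT assay, with a stated time of 72 h (a higher number here means a weaker inhibitor, a lower number a stronger inhibitor), compound 3 (`Cc1nc(N)c2c(-c3cc4ccccc4o3)cn([C@@H]3O[C@H](CO)[C@@H](O)[C@H]3O)c2n1`) gives 13100 nM as the only true number so far. Compound 1 (`Cc1nc(N)c2c(-c3ccoc3)cn([C@@H]3O[C@H](CO)[C@@H](O)[C@H]3O)c2n1`) gives > 20000 nM as a limit of the assay. Compound 2 (`Cc1nc(N)c2c(-c3ccsc3)cn([C@@H]3O[C@H](CO)[C@@H](O)[C@H]3O)c2n1`) gives > 20000 nM as a limit too. The step to compound 4 (`Cc1nc(N)c2c(I)cn([C@@H]3O[C@H](CO)[C@@H](O)[C@H]3O)c2n1`) puts iodo in place of 1-benzofuran-2-yl on an aromatic carbon. Two measured steps change the group at this place, an at least 1.5-fold lower number from compound 1 to compound 3 (0.18 log units; that floor lies within the scatter) and an at least 1.5-fold lower number from compound 2 to compound 3 (0.18 log units; that floor lies within the scatter), and both floors lie within the scatter. Going by the values given here, no measured step brings in iodo. No step beyond the scatter is therefore expected in this assay, and the estimated change is a 1.1-fold higher number from compound 3 to compound 4 (0.06 log units; within the scatter) in size. Compound 4 is estimated at 15000 nM in the middle, with 4000 nM to 40000 nM as the expected range around it.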

Compound 4, half-maximal inhibitory concentration: > 20000 nM
Compound 4 ended at the assay's limit; the forecaster's own chance of this, stated with the estimate: 55%; middle value at least 1.3-fold (0.12 log units) away from the limit.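

In this assay, for the compounds shown here, a single iodo atom at this place, the first group here with no ring, gives an at least 1.5-fold higher number from compound 3 to compound 4 (0.18 log units; that floor lies within the scatter). Going by these compounds alone, compound 4 carries a limit of the assay, so compound 3 remains the only compound with a true number. The steps from compound 1 and compound 2 to compound 4 cannot be read, because both ends of each are limits: the limit of > 20000 nM in this assay, at which 3 of the 4 values shown sit.

Going by these compounds, it remains open whether an amine, a carboxylic acid or a longer chain at this place would give a true number in this assay. A phenyl group, a single six-membered aromatic ring of carbon only, also remains untested among these compounds.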